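Swapping the Hydrazone Aryl Group in an Acylurea Thiazole Series

The source may hold more compounds than are shown below. What is called first, only, known or untested is meant among the compounds shown, and "the series" means these compounds.

Measured so far:
compound 1 `CN(C(=O)NC(=O)c1ccc(Cl)cc1Cl)c1nc(C(F)(F)F)c(C(=O)N/N=C/c2cccc(C(F)(F)F)c2)s1`: 11.2 ug/mL
compound 2 `CN(C(=O)NC(=O)c1ccc([N+](=O)[O-])cc1)c1nc(C(F)(F)F)c(C(=O)N/N=C/c2ccc([N+](=O)[O-])cc2)s1`: 12.3 ug/mL

Both compounds were tested in a functional assay on HepG2 cells (Homo sapiens) for inhibition, read by MTT assay, with a stated time of 72 h; on this read-out higher numbers stand for weaker inhibition and lower numbers for stronger inhibition. Compound 2 has the higher of the two numbers, but its nearest neighbour, compound 1, sits within the scatter of it, so the two cannot be told apart. Compound 3 `CN(C(=O)NC(=O)c1ccc([N+](=O)[O-])cc1)c1nc(C(F)(F)F)c(C(=O)N/N=C/c2cccc(C(F)(F)F)c2)s1` has not been measured. It differs from compound 2 by 3-(trifluoromethyl)phenyl in place of 4-nitrophenyl on a carbon with a double bond to nitrogen. Compound 1 already carries that same group in the same place and gave 11.2 ug/mL, so no step beyond the scatter is expected a 1.1-fold lower number from compound 2 to compound 3 (0.03 log units; within the scatter). Compound 3 is expected to give about 11.5 ug/mL, with a range from 6 ug/mL to 23 ug/mL.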

Compound 3, half-maximal inhibitory concentration: 4.73 ug/mL
Estimate against measurement, compound 3: 2.4-fold (0.39 log units) above; the measured number lies below the stated range.
By their numbers in this assay, from the lowest: compound 3; then compounds 1 and 2 (each within the scatter of the next).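

In this assay putting 3-(trifluoromethyl)phenyl in place of 4-nitrophenyl on the carbon with a double bond to nitrogen gives a 2.6-fold lower number from compound 2 to compound 3 (0.42 log units; beyond the scatter) with 4-nitrophenyl held on the carbonyl carbon. Putting 4-nitrophenyl in place of 2,4-dichlorophenyl on the carbonyl carbon gives a 2.4-fold lower number from compound 1 to compound 3 (0.37 log units; beyond the scatter) with 3-(trifluoromethyl)phenyl held in the other place, so each place can move the number, which compound 1 and compound 2, within the scatter of each other, did not reveal. Nothing measured here accounts for either step. As far as these compounds go, whether an amine or a carboxylic acid on either phenyl ring would move the number further remains open.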